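Removing the methoxycarbonyl group from compound 1

A few compounds are considered here, and "the series" means these few. Any claim that something is new, unique, unknown or untested is made for them only; others in the source may bear on it.

Measured in an ADME assay on K562 cells (Homo sapiens) for antiproliferative activity, with a stated time of 72 h; a lower number here means a stronger inhibitor of growth, a higher number a weaker inhibitor of growth:
Compound 1 `COC(=O)C1CN(c2nc(=O)c3cc(C(F)(F)F)cc([N+](=O)[O-])c3s2)CCC12OC[C@H](C)O2`: 22000 nM
Compound 2 `CN(c1nc(=O)c2cc(C(F)(F)F)cc([N+](=O)[O-])c2s1)[C@H]1CCN(Cc2ccccc2)C1`: 30000 nM
Compound 3 `O=c1nc(N2CCC(F)(F)CC2)sc2c([N+](=O)[O-])cc(C(F)(F)F)cc12`: "not determined" (no result reported)

For the measured compounds named here, only two numbers are available in this assay. Going by the values given here, compound 1 (at 22000 nM) and compound 2 (at 30000 nM) lie within the usual scatter of each other, so compound 1 cannot be separated from its only numerical neighbour.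

Compound 4 `C[C@H]1COC2(CCN(c3nc(=O)c4cc(C(F)(F)F)cc([N+](=O)[O-])c4s3)CC2)O1` has not yet been measured. Compared with compound 1, it has hydrogen in place of methoxycarbonyl on a saturated ring carbon.

Among the compounds with values here, no measured pair differs in just one place, so the data offer no direct guide to the size of this step. The only hint is that two different compounds share a similar level of weak growth inhibition, and two numbers cannot establish a trend. The expectation is therefore no step beyond the scatter in either direction, with a wide range to reflect that uncertainty. The estimate means a 1.1-fold higher number from compound 1 to compound 4 (0.06 log units; within the scatter) as the expected step. Compound 4 is estimated at 25000 nM with 10000 nM to 60000 nM as the expected range.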

Compound 4, concentration for 50% growth inhibition: 11000 nM
Compound 4: middle estimate off by 2.3-fold (0.36 log units), on the high side; low and high end bracket the measured number.
By their numbers in this assay, from the lowest: compounds 4, 1 and 2 (each within the scatter of the next, the first and the last beyond it).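

In this assay, hydrogen in place of methoxycarbonyl on a saturated ring carbon gives a 2.0-fold lower number from compound 1 to compound 4 (0.30 log units; within the scatter). For the compounds shown here, this is the first direct comparison at this position, and it shows that the methoxycarbonyl group can leave this ring carbon without a difference that the assay can separate from ordinary scatter, with growth inhibition remaining weak. No accompanying measurement offers an explanation for this result.

With only methoxycarbonyl and hydrogen compared here, a single step cannot show how sensitive this position is to what it carries. From the compounds shown here alone, it remains open whether a carboxylic acid, an amine or a longer chain on the same ring carbon would give a step beyond the scatter in either direction.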